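A few compounds are considered here, and "the series" means these few. Any claim that something is new, unique, unknown or untested is made for them only; others in the source may bear on it.

Measured compounds:
- compound 1, `NCc1ccc(C(=O)Nc2ccncc2F)cc1-c1cccc(C(=O)Nc2cccc(CC(=O)O)c2)c1`: 1.5 nM
- compound 2, `CCCOC(=O)c1cccc(C(=O)Nc2cccc(-c3cc(C(=O)Nc4ccncc4F)ccc3CN)c2)c1`: 1.8 nM
- compound 3, `CCCOC(=O)c1ccc(F)c(NC(=O)c2cccc(-c3cc(C(=O)Nc4ccncc4F)ccc3CN)c2)c1`: 2.1 nM

In an assay on cells for inhibition of Rho-associated protein kinase 2 (Homo sapiens), read by radiometric assay and 33P incorporation, in the presence of a further agent that is not named here (on this read-out lower numbers stand for stronger inhibition and higher numbers for weaker inhibition), compound 1 gives the lowest of the three numbers, but compound 2 and compound 3 sit within the scatter of it, so the three read as one level. Compound 4, `NCc1ccc(C(=O)Nc2ccncc2F)cc1-c1cccc(C(=O)Nc2ccccc2)c1`, has not yet been measured. It differs from compound 1 in one place: hydrogen in place of carboxymethyl on an aromatic carbon. For the measured compounds named here, no step between measured compounds tracks this change, so the expectation rests on the narrow spread of the three values: varied groups at that end of the core leave the numbers close. A small loss beyond the scatter is expected at most; the estimated step of a 2.3-fold higher number from compound 1 to compound 4 (0.37 log units; beyond the scatter) is modest. Compound 4 is expected at 3.5 nM, within 1.2 nM to 12 nM.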

Compound 4, half-maximal inhibitory concentration: < 1 nM
Compound 4: no number, only a limit (the forecaster's own chance of this, stated with the estimate: 2%); middle value at least 3.5-fold (0.54 log units) away from the limit.
By their numbers in this assay, from the lowest: compounds 1, 2 and 3 (each within the scatter of the next). At a limit, below all of these: compound 4.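

In this assay compound 4 gives < 1 nM, a limit of the assay and not a number. Carboxymethyl on this aromatic carbon is not required for inhibition at this level, and the plain anilino end keeps it, with an at least 1.5-fold lower number from compound 1 to compound 4 (0.17 log units; that floor lies within the scatter). How far the true value of compound 4 lies past that limit cannot be read: the limit of < 1 nM in this assay, at which 1 of the 4 values shown sits.

As far as these compounds go, whether an amine or a longer carboxylic acid chain in place of the hydrogen would hold this level remains open. With the series at the limit of the assay, any gain from such a group could not be read here.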